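Terminal ring swap at the chain end of compound 3

A few compounds are considered here, and "the series" means these few. Any claim that something is new, unique, unknown or untested is made for them only; others in the source may bear on it.

Compound 3 `O=C(CCCCCCc1ccccn1)c1ncc(-c2ccccn2)o1` gives the lowest number of the three measured compounds in an assay for inhibition of Fatty-acid amide hydrolase 1 (Rattus norvegicus); on this read-out lower numbers stand for stronger inhibition and higher numbers for weaker inhibition: compound 3 gives 120 nM. Its nearest neighbour is compound 2 `O=C(CCCCC#Cc1ccncc1)c1ncc(-c2ccccn2)o1`, which in this assay gives 150 nM, and the furthest is compound 1 `O=C(CCCCC#Cc1cccnc1)c1ncc(-c2ccccn2)o1`, which gives 300 nM.

Compound 4 `O=C(CCCCCCc1ccc(Cl)cc1)c1ncc(-c2ccccn2)o1` is not yet measured. It differs from compound 3 as follows: 4-chlorophenyl in place of pyridin-2-yl on a saturated chain carbon, six bonds along the chain from a carbonyl carbon.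

Among the measured steps, none removes the ring nitrogen altogether or exchanges a pyridyl for a carbon-only ring. The step of a 2.0-fold lower number from compound 1 to compound 2 (0.30 log units; within the scatter) shows that moving the nitrogen within the terminal ring changes little. The steps of a 2.5-fold lower number from compound 1 to compound 3 (0.40 log units; beyond the scatter) and a 1.3-fold lower number from compound 2 to compound 3 (0.10 log units; within the scatter) each alter the linker and the ring at once, and only one of them exceeds the scatter, and that modestly. No measured step therefore speaks directly to losing the single acceptor on the terminal ring, and no reason is visible to expect more than a small shift in this assay.

For compound 4 the expected value is 150 nM, with a range of 50 nM to 450 nM; this is estimated as a step of a 1.3-fold higher number from compound 3 to compound 4 (0.10 log units; within the scatter), close to the scatter.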

Compound 4, inhibition constant: 2.7 nM
Compound 4: the middle estimate sits 56-fold (1.74 log units) above what was measured, and the stated range ends above it.
By their numbers in this assay, from the lowest: compound 4; then compounds 3, 2 and 1 (each within the scatter of the next, the first and the last beyond it).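

In this assay, within the data shown here, the terminal ring at the end of the saturated chain proves far more sensitive than the steps among compounds 1, 2 and 3 indicated: exchanging pyridin-2-yl for 4-chlorophenyl gives a 44-fold lower number from compound 3 to compound 4 (1.65 log units; beyond the scatter) and is the only large step so far. The change replaces a six-membered aromatic ring with 1 hetero atom and 1 hydrogen-bond acceptor by a ring of carbon only that carries chlorine, so this single step combines loss of the ring nitrogen with gain of the chlorine. Nothing at hand accounts for the size of this step.

Open, on these data alone, is how much of the step belongs to the carbon-only ring and how much to the chlorine; an unsubstituted phenyl and a 4-fluorophenyl at this chain end would help to separate the two. Also open, as far as these compounds go, is whether the 4-chlorophenyl keeps this standing on a shorter or longer chain, or on the triple-bonded linker of compounds 1 and 2.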